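Ring swap on a charged chain end

The source may hold more compounds than are shown below. What is called first, only, known or untested is meant among the compounds shown, and "the series" means these compounds.

Measured so far:
Compound 1, `CN(C)c1ccc2c(=O)c(C(=O)Nc3cc(F)cc(F)c3)cn(-c3ccc(Cl)c(OCCCCCCC[N+]4(C)CCCCC4)c3)c2n1`: 57.3%
Compound 2, `CN(C)c1ccc2c(=O)c(C(=O)Nc3cc(F)cc(F)c3)cn(-c3ccc(Cl)c(OCCCCCCC[n+]4ccccc4)c3)c2n1`: "not active" (no number reported)

Two compounds share the same core and differ only in the charged group at the end of the seven-carbon chain. In an assay on LX2 cells for inhibition of COL1A1 promoter (Homo sapiens), read by a luciferase reporter, with a stated time of 24 h, tested at 20 uM (a higher number here means a stronger effect of the compound at the concentration tested, a lower number a weaker effect), compound 1 gives 57.3%. In the same assay compound 2 is reported as "not active" (no number reported), with no number attached, so compound 2 stands at the inactive end of what has been seen, while compound 1 stands well above it.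

Compound 3, `CC[N+]1(CCCCCCCOc2cc(-n3cc(C(=O)Nc4cc(F)cc(F)c4)c(=O)c4ccc(N(C)C)nc43)ccc2Cl)CCCCC1`, has not yet been measured. It differs from compound 2 in one place: a group of 8 heavy atoms (7 carbon, 1 nitrogen; one six-membered non-aromatic ring with 1 hetero atom) in place of a group of 6 heavy atoms (5 carbon, 1 nitrogen; one six-membered aromatic ring with 1 hetero atom), on a saturated chain carbon, seven bonds along the chain from an oxygen on an aromatic ring. The entering group is close to the charged ring of compound 1, which gave 57.3%, so compound 3 is expected to move upward from compound 2 in this assay by a step clearly beyond the scatter, toward the level of compound 1. Among the measured compounds shown here, with only two measured compounds, neither a pattern nor a firm size can be claimed. Compound 3 is estimated to give about 45%, within a range of 15% to 70%.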

Compound 3, a percentage reported as inhibition, at one concentration (the size of the read-out at that concentration, not a potency): "not active" (no number reported)
Compound 3: no number reported; the estimate stays without a comparison.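

In this assay, among the compounds shown here, compound 2 gives "not active" (no number reported) and compound 3 gives "not active" (no number reported), so no step between them can be read. Nothing at hand bears on this result. The compounds shown leave open whether compound 2 and compound 3 truly differ, and what sets compound 1, at 57.3%, apart from them.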